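Swapping Chloro for Fluoro at the Assay Limit

The source may hold more compounds than are shown below. What is called first, only, known or untested is meant among the compounds shown, and "the series" means these compounds.

Measured in a functional assay on SW-620 cells (Homo sapiens); on this read-out higher numbers stand for weaker inhibition of growth and lower numbers for stronger inhibition of growth:
- Compound 1 `O=S(=O)(/C=C/c1ccc(Cl)cc1Cl)Cc1ccc(Nc2ncnc3ccccc23)cc1`: 14000 nM
- Compound 2 `O=S(=O)(/C=C/c1ccc(O)cc1)Cc1ccc(Nc2ncnc3ccc(Br)cc23)cc1`: 94000 nM
- Compound 3 `O=S(=O)(/C=C/c1ccc(Cl)cc1Cl)Cc1ccc(Nc2ncnc3cc(Cl)ccc23)cc1`: > 100000 nM (a limit, not a number)

Compound 3 stands at the limit of > 100000 nM in this assay, at which 1 of the 3 values shown sits, so it has no exact number. Compound 4 `O=S(=O)(/C=C/c1ccc(F)cc1Cl)Cc1ccc(Nc2ncnc3cc(Cl)ccc23)cc1` differs from compound 3 in one place: fluoro in place of chloro on an aromatic carbon. Going by the values given here, the only measured step, an at least 7.1-fold higher number from compound 1 to compound 3 (0.85 log units; beyond the scatter), is a different change, chloro in place of hydrogen on an aromatic carbon. Among the compounds with values here, no measured step swaps these two groups, so no step beyond the scatter is expected in this assay, and no direction can be given. The expected step is an at least 1.2-fold lower number from compound 3 to compound 4 (0.09 log units; that floor lies within the scatter). Compound 4 is expected at 80000 nM, within an estimated range of 25000 nM to 150000 nM.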

Compound 4, concentration for 50% growth inhibition: > 100000 nM
Compound 4 was reported as a limit; the forecaster's own chance of this, stated with the estimate: 50%; middle value at least 1.2-fold (0.09 log units) away from the limit.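

Compound 3 and compound 4 both stand as limits rather than numbers, so no step can be read between them: the limit of > 100000 nM in this assay, at which 2 of the 4 values shown sit.

As far as these compounds go, whether fluoro in place of chloro changes the result in this assay stays open.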